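Swapping the aryl group on the thiazole of compound 3

The compounds below may be only part of what the source reports. "The series", "measured", "known", "first", "only" and "open" are said of these compounds alone.

Three hydrazone compounds sharing one core have been measured in a functional assay on Caco-2 cells (Homo sapiens) for inhibition, read by MTT assay, with a stated time of 48 h; on this read-out higher numbers stand for weaker inhibition and lower numbers for stronger inhibition. Compound 1 `COc1cc(/C=N/Nc2nc(-c3cccc(Br)c3)cs2)cc(Br)c1OC` gives 43400 nM. Compound 2 `COc1cc(/C=N/Nc2nc(-c3ccc(F)c(F)c3)cs2)cc(Br)c1OC` gives 21200 nM, and compound 3 `COc1cc(/C=N/Nc2nc(-c3ccc(F)c(F)c3)cs2)c(Br)c(Br)c1OC` gives 22800 nM. Between them, the change a 2.0-fold lower number from compound 1 to compound 2 (0.31 log units; beyond the scatter) is the only step beyond the scatter, whereas a 1.1-fold higher number from compound 2 to compound 3 (0.03 log units; within the scatter) is not. On the numbers shown, compound 3 holds the second highest of the three, with its gaps to compound 2 and to compound 1 both inside the scatter.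

Compound 4 `COc1cc(/C=N/Nc2nc(-c3cccc(Br)c3)cs2)c(Br)c(Br)c1OC` differs from compound 3 by one exchange: 3-bromophenyl in place of 3,4-difluorophenyl on an aromatic carbon. For the measured compounds named here, the only measured step bearing on this is the one from compound 1 to compound 2, which made the same exchange in the opposite direction, on the core lacking the second bromo group, and gave a modest fall of the number. Reversing it on the dibrominated core, a modest rise of the number is expected in this assay, of about the same size as that earlier step, because a 2.0-fold lower number from compound 1 to compound 2 (0.31 log units; beyond the scatter) was the only change beyond the scatter seen here.

Compound 4 is therefore estimated at 45000 nM, within a range from 22000 nM to 90000 nM, which is the expected step of a 2.0-fold higher number from compound 3 to compound 4 (0.30 log units; within the scatter).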

Compound 4, half-maximal inhibitory concentration: > 100000 nM
Compound 4 gave a limit, no number; the forecaster's own chance of this, stated with the estimate: 10%; middle value at least 2.2-fold (0.34 log units) from the limit.
By their numbers in this assay, from the lowest: compounds 2, 3 and 1 (each within the scatter of the next, the first and the last beyond it). At a limit, above all of these: compound 4.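

Compound 4 gives > 100000 nM in this assay, which is a limit of the assay and not a number. At this position, next to the ring nitrogen, 3-bromophenyl in place of 3,4-difluorophenyl now gives an at least 4.3-fold higher number from compound 3 to compound 4 (0.64 log units; beyond the scatter), so the exchange moves the read-out beyond the scatter on a second core and in the same direction as on the first: the same change on two cores in this assay, a 2.0-fold lower number (0.31 log units; beyond the scatter) from compound 1 to compound 2 and an at least 4.3-fold lower number (0.64 log units; beyond the scatter) from compound 4 to compound 3; the limit leaves it open whether they differ The bromo in place of hydrogen, which stayed within the scatter with 3,4-difluorophenyl at this position, gives an at least 2.3-fold higher number from compound 1 to compound 4 (0.36 log units; beyond the scatter) with 3-bromophenyl there, so this change is no longer without a visible step on every core shown: the same change on two cores in this assay, a 1.1-fold higher number (0.03 log units; within the scatter) from compound 2 to compound 3 and an at least 2.3-fold higher number (0.36 log units; beyond the scatter) from compound 1 to compound 4; the limit leaves it open whether they differ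

The compounds shown do not separate what the bromine of the 3-bromophenyl group contributes from what the two fluorines of the 3,4-difluorophenyl group contribute, and a plain phenyl or a 3-chlorophenyl group at this position would bear on that. Also open, going by these compounds, is how this position responds to a group of another kind, such as an aminophenyl group or a phenyl ring carrying a carboxylic acid, on either core.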